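The compounds below may be only part of what the source reports. "The series", "measured", "known", "first", "only" and "open" are said of these compounds alone.

Working notes on the series. Of the compounds shown here, two have numbers so far. Compound 1, `O=C(O)c1ccc(-n2cc(C(=O)c3c(Cl)cccc3Cl)c3cccnc32)cc1`, in an ADME assay on microsomes from liver (Rattus norvegicus) for metabolic stability, read by LC-MS, using NADPH, with stated times of 5 min and 30 min, tested at 1 uM (on this read-out lower numbers stand for a less stable compound and higher numbers for a more stable compound), gives 100%. Compound 2, `O=C(O)c1ccc(-n2cc(C(=O)c3c(Cl)cccc3C(F)(F)F)c3cccnc32)c(F)c1`, in this assay gives 73%, the lower of the two numbers; compound 1 sits higher by a gap beyond the scatter. Among the measured compounds shown here, compound 1 and compound 2 differ in two places, so no single step between them can be read from these two values alone.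

The next compound, compound 3, is `O=C(O)c1ccc(-n2cc(C(=O)c3c(Cl)cccc3C(F)(F)F)c3cccnc32)cc1`; it carries the trifluoromethyl of compound 2 and differs from compound 2 by one change: hydrogen in place of fluoro on an aromatic carbon. Cut one bond further out, the same difference reads 4-carboxy-2-fluorophenyl to 4-carboxyphenyl.

For the measured compounds named here, with no measured single step of this kind, the size of the step is open. Compound 1, which also has no fluoro on that ring, gives 100%, so a rise for compound 3 relative to compound 2 is expected, though it could fall within the scatter. For compound 3 the expected value in this assay is 85%, with a range from 65% to 100%, a step from compound 2 to compound 3 estimated as a number 12 percentage points higher from compound 2 to compound 3 (beyond the scatter).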

Compound 3, percent of the compound remaining: 55%
The estimate for compound 3 lay 30 percentage points above the measured number, outside the stated range (below it).
By their numbers in this assay, from the lowest: compound 3; then compound 2; then compound 1.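

In this assay, the change from 4-carboxy-2-fluorophenyl to 4-carboxyphenyl, with the trifluoromethyl kept, gives a number 18 percentage points lower from compound 2 to compound 3 (beyond the scatter), so at this place on an aromatic carbon, ortho to a large group and meta to a carboxy group, the compound with fluoro carries the higher number of the pair. Among the compounds shown here, with 4-carboxyphenyl held constant, trifluoromethyl in place of chloro on an aromatic carbon gives a number 45 percentage points lower from compound 1 to compound 3 (beyond the scatter), a step classed as large where the fluoro step is classed as modest, and the first single-change reading at that position. Nothing at hand bears on why either step takes the size it does.

The compounds shown leave open whether the fluoro step keeps its direction and size when chloro stands in place of the trifluoromethyl, since the single change has been read only with trifluoromethyl present. They also leave open how a methoxy group or an amine would read at the fluoro place, and how a nitrile would read in place of the trifluoromethyl.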